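From 4-chlorophenyl to 4-fluorophenyl: working notes

The compounds below may be only part of what the source reports. "The series", "measured", "known", "first", "only" and "open" are said of these compounds alone.

Measured compounds, all in a functional assay on A549 cells (Homo sapiens) for antiproliferative activity, read by MTT assay, with a stated time of 48 h; on this read-out lower numbers stand for stronger inhibition and higher numbers for weaker inhibition:
- compound 1 `Cc1ccc2nc(NC(c3cn(-c4ccccc4)nc3-c3cccc(Cl)c3)c3c(O)ccc4ccccc34)sc2c1` gives 45400 nM
- compound 2 `Oc1ccc2ccccc2c1C(Nc1nc2ccccc2s1)c1cn(-c2ccccc2)nc1-c1ccc(I)cc1` gives 23100 nM
- compound 3 `COc1ccc2nc(NC(c3cn(-c4ccccc4)nc3-c3ccc(Cl)cc3)c3c(O)ccc4ccccc34)sc2c1` gives 34500 nM

Compound 3 sits within the scatter of both compound 1 and compound 2, so these numbers give no ranking around it. Among the measured compounds shown here, no two measured compounds differ in only one place, which leaves no direct step to read across.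

Compound 4 `COc1ccc2nc(NC(c3cn(-c4ccccc4)nc3-c3ccc(F)cc3)c3c(O)ccc4ccccc34)sc2c1` has not been measured. It carries fluoro in place of chloro on an aromatic carbon, para to a large group (fluoro in place of chloro on an aromatic carbon).

With all of this resting on compound 3 (34500 nM), no step beyond the scatter is expected in this assay, and neither direction is favoured. The estimated change is small, a 1.1-fold lower number from compound 3 to compound 4 (0.05 log units; within the scatter). For compound 4 the estimated value is 31000 nM, with an expected range from 15000 nM to 62000 nM.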

Compound 4, half-maximal inhibitory concentration: 33600 nM
Estimate against measurement, compound 4: 1.1-fold (0.03 log units) below; the measured number falls inside the stated range.
By their numbers in this assay, from the lowest: compounds 2, 4, 3 and 1 (each within the scatter of the next).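

In this assay, among the compounds shown here, the change from 4-chlorophenyl to 4-fluorophenyl gives a 1.0-fold lower number from compound 3 to compound 4 (0.01 log units; within the scatter), the first direct step. On the core of compound 3, then, fluoro can stand in place of chloro at this position, on an aromatic carbon para to a large group, without a step beyond the scatter. No measurement of any property is available that bears on this result.

As far as these compounds go, whether an amine, a carboxylic acid or a nitrile at this position would also leave the number within the scatter remains open. From the compounds shown here alone, it is equally open whether the change from chloro to fluoro would read the same on the core of compound 1 or of compound 2, since this single step comes from one core only.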